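From propoxy to fluoro: a step among limits

The source may report more compounds than this note shows. Statements on the series, on what has been measured and on what is new or still open speak of the compounds shown alone.

Compound 2 (`CCCOc1cccc(-c2[nH]c3cc(OC)ccc3c(=O)c2C(=O)OCC)c1`) has been tested in an ADME assay on HEK293 cells (Homo sapiens) for cytotoxicity, read by luminescence, with a stated time of 72 h (a higher number here means that more compound is needed for the effect, a lower number that less compound is needed), and gives > 22000 nM there, which is a limit and not a number. Compound 1 (`CCOC(=O)c1c(-c2ccccc2)[nH]c2cc(OC)ccc2c1=O`) gives > 22000 nM in the same test, also a limit. Compound 3 (`CCOC(=O)c1c(-c2cccc(OCc3ccccc3)c2)[nH]c2cc(OC)ccc2c1=O`) gives > 22000 nM there, again a limit. Among the measured compounds shown here, the whole picture so far is the limit of > 22000 nM in this assay, at which 3 of the 3 values shown sit, and no compound can be ranked against another.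

Compound 4 (`CCOC(=O)c1c(-c2cccc(F)c2)[nH]c2cc(OC)ccc2c1=O`) is still unmeasured. It carries fluoro in place of propoxy on an aromatic carbon, meta to a large group (fluoro in place of propoxy on an aromatic carbon) and is otherwise the same as compound 2.

Two measured changes come closest. Propoxy in place of hydrogen gives a step that the two limits leave unreadable from compound 1 to compound 2 and benzyloxy in place of hydrogen gives a step that the two limits leave unreadable from compound 1 to compound 3 so neither offers a size to carry over. Swapping phenyl for ethyl on the ether chain gives a step that the two limits leave unreadable from compound 2 to compound 3 and adds no size either.

With compound 1 and compound 2 both at the limit, no step beyond the usual scatter is expected in this assay and no direction can be given. The estimated change is a step that the limit leaves unreadable from compound 2 to compound 4 on this reading. The expected value for compound 4 is 30000 nM with an estimated range from 15000 nM to 60000 nM and most likely only a limit will be reported.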

Compound 4, half-maximal effective concentration: > 22000 nM
Compound 4 was reported as a limit; the forecaster's own chance of this, stated with the estimate: 85%; the middle value is on the limit's open side.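

Compound 4 also gives only a limit, so the steps to it from compound 1, compound 2 and compound 3 cannot be read, and no new comparison arises: the limit of > 22000 nM in this assay, at which 4 of the 4 values shown sit.

The compounds shown leave open how far apart these four truly lie in this assay, and whether any change on this aromatic carbon would give a readable number.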